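Indole-substituted amino-dicarbonitrile series: aryl swap on saturated carbon

The source may report more compounds than this note shows. Statements on the series, on what has been measured and on what is new or still open speak of the compounds shown alone.

Measured compounds:
- compound 1 `N#CC1=C(N)OC(c2c[nH]c3ccccc23)=C(C#N)C1c1ccccc1F`: "not active" (no number reported) in a functional assay, tested at 200 ug/mL; on this read-out higher numbers stand for a stronger effect at the one concentration tested and lower numbers for a weaker effect
- compound 2 `COc1ccc(C2C(C#N)=C(N)OC(c3c[nH]c4ccccc34)=C2C#N)cc1OC`: 26.1% in this assay

Compound 1 is reported in this assay only as not active, without a number. Compound 2 therefore holds the only number in the series, and nothing shown reaches beyond it. Among the measured compounds shown here, no step between two measured compounds is available, so the effect of changing the aryl group on the saturated ring carbon is not yet known from data.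

Compound 3 `CN(C)c1ccc(C2C(C#N)=C(N)OC(c3c[nH]c4ccccc34)=C2C#N)cc1` differs from compound 2 by one change: 4-(dimethylamino)phenyl in place of 3,4-dimethoxyphenyl on a saturated ring carbon. For the measured compounds named here, with compound 2 at 26.1% and no measured step to lean on, the step from compound 2 to compound 3 is expected to be small, within or only slightly beyond the scatter, and its direction is not settled. Compound 3 is therefore estimated at 28% in this assay, within 8% to 55%, meaning an expected step of a number 1.9 percentage points higher from compound 2 to compound 3 (within the scatter).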

Compound 3, a percentage reported as activity, at one concentration (the size of the read-out at that concentration, not a potency): 20.5%
Compound 3: the middle estimate sits 7.5 percentage points above what was measured, and the stated range covers the measured number.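

In this assay, among the compounds shown here, the first measured step at this saturated ring carbon is a number 5.6 percentage points lower from compound 2 to compound 3 (within the scatter) and so gives no separation between the two compounds. Replacing 3,4-dimethoxyphenyl with 4-(dimethylamino)phenyl, which swaps two oxygen-bearing groups for one nitrogen-bearing group on the same aromatic ring, therefore leaves the read-out where the scatter cannot tell the two apart, and this holds for this one pair only. No measurement on hand bears on this result, so it stands without an explanation.

Steps involving compound 1 cannot be read, as its result carries no number, so whether a change at this carbon can move the read-out beyond the scatter stays open. Also open, from the compounds shown here alone, is how a carboxylic acid on the phenyl ring, or a cyclohexyl group in its place, would read in this assay at this position.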